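Lengthening the Methoxycarbonyl Side of a Dihydropyridine-Type Core

A few compounds are considered here, and "the series" means these few. Any claim that something is new, unique, unknown or untested is made for them only; others in the source may bear on it.

Compound 1 `CCOC(=O)C1=C(C)NC(C)=C(C(=O)OC)C1c1cnc(SC)n1Nc1ccccc1` is the reference point. In an assay on isolated protein (strain albino) for antagonist activity at Voltage-dependent L-type calcium channel subunit alpha-1C (Cavia porcellus) (a lower number here means a stronger inhibitor, a higher number a weaker inhibitor), compound 1 gives 1.66 nM, the lowest of the two numbers available, with compound 2 `CCCOC(=O)C1=C(C)NC(C)=C(C(=O)OC)C1c1cnc(SC)n1Nc1ccccc1` closest at 2.4 nM; the step of a 1.4-fold higher number from compound 1 to compound 2 (0.16 log units; within the scatter) lies within the scatter. The unmeasured compound 3 `CCOC(=O)C1=C(C)NC(C)=C(C(=O)OCCCc2ccccc2)C1c1cnc(SC)n1Nc1ccccc1` differs from compound 1 by phenethyl in place of hydrogen on a saturated chain carbon bound to an oxygen next to a carbonyl group. Among the measured compounds shown here, only one measured step exists, a 1.4-fold higher number from compound 1 to compound 2 (0.16 log units; within the scatter), and it sits on a different chain of the shared core and adds far less than what enters in compound 3, so it bears on the new change only loosely. From that small step, the expectation for compound 3 in this assay is a modest move, if any, and the direction cannot be fixed from the two numbers alone. Compound 3 is therefore estimated at 3 nM, within a range of 0.8 nM to 12 nM, which corresponds to an expected step of a 1.8-fold higher number from compound 1 to compound 3 (0.26 log units; within the scatter).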

Compound 3, half-maximal inhibitory concentration: 2.54 nM
Estimate against measurement, compound 3: 1.2-fold (0.07 log units) above; the range from low to high includes it.
By their numbers in this assay, from the lowest: compounds 1, 2 and 3 (each within the scatter of the next).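

In this assay, the change from methoxycarbonyl to (3-phenylpropoxy)carbonyl gives a 1.5-fold higher number from compound 1 to compound 3 (0.18 log units; within the scatter), so a chain carrying 8 more heavy atoms and one six-membered aromatic ring of carbon leaves the number within the scatter. The earlier pair showed only the addition of a methyl on the other chain of the shared core, whereas this step shows that a much larger change at this position also stays within the scatter. No measurement at hand accounts for this result.

The compounds shown leave open whether a dimethylamino group or a carboxylic acid at the end of this chain, in place of the phenyl ring, would keep the number within the scatter of compound 1. They also leave open whether a longer chain would do so, and whether 3-phenylpropyl would give the same outcome on the other chain.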